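Replacing a nitro group on compound 1

A few compounds are considered here, and "the series" means these few. Any claim that something is new, unique, unknown or untested is made for them only; others in the source may bear on it.

Among the measured compounds shown here, in a functional assay on DU-145 cells (Homo sapiens) for cytotoxicity, read by trypan blue exclusion, with a stated time of 96 h (on this read-out higher numbers stand for weaker inhibition and lower numbers for stronger inhibition), compound 1 (`COc1cc(OC)c(/C=C/S(=O)(=O)Nc2cc([N+](=O)[O-])c(OC)c([N+](=O)[O-])c2)c(OC)c1`) gives 10000 nM, the lower of the two numbers measured so far. Compound 2 (`COc1ccc(/C=C/S(=O)(=O)Nc2c(F)c(F)c(F)c(F)c2F)cc1N`) gives 35000 nM, a gap beyond the scatter, but the two structures differ in more than one place, so the gap says little about any single group. Compound 3 (`COc1cc(OC)c(/C=C/S(=O)(=O)Nc2ccc(OC)c([N+](=O)[O-])c2)c(OC)c1`) keeps the core of compound 1, with hydrogen in place of nitro on an aromatic carbon. For the measured compounds named here, no measured pair shows this change, so the expectation is a judgement with wide margins. In this assay a sizeable move toward stronger inhibition is expected, well beyond the scatter, and the estimated step is a 17-fold lower number from compound 1 to compound 3 (1.22 log units; beyond the scatter). For compound 3 the expected value is 600 nM, with an estimated range of 60 nM to 6000 nM.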

Compound 3, half-maximal inhibitory concentration: 2500 nM
For compound 3 the middle estimate is 4.2-fold (0.62 log units) below the measured one; the range from low to high includes it.
By their numbers in this assay, from the lowest: compound 3; then compound 1; then compound 2.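

In this assay, among the compounds shown here, hydrogen in place of nitro on an aromatic carbon gives a 4.0-fold lower number from compound 1 to compound 3 (0.60 log units; beyond the scatter) and provides the first reading of a single change. The nitro group ortho to a methoxy group and meta to the second nitro group is therefore not required for the inhibition seen with compound 1, and the series keeps its inhibition, with a modest gain, when this place loses those 3 heavy atoms. Nothing available explains the size or direction of this step.

On these data alone, whether a nitrile or a carboxylic acid at this place would give a lower or higher number than hydrogen remains open. As far as these compounds go, it is also open whether the remaining nitro group of compound 3 can be replaced in the same way, since this single pair covers only one of the two places.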